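Series notes: the step from compound 3 to compound 4

A few compounds are considered here, and "the series" means these few. Any claim that something is new, unique, unknown or untested is made for them only; others in the source may bear on it.

Compound 3 `Cc1cccc(S(=O)(=O)N2CCC(N3CCC(C)CC3)CC2)c1` stands only at a limit in an ADME assay on HCT-116 cells (Homo sapiens) for cytotoxicity, read by CellTiter-Glo, with a stated time of 72 h; a higher number here means a weaker inhibitor, a lower number a stronger inhibitor: compound 3 gives > 5000 nM, which is a limit of the assay and not a number. Compound 1 `CC1CCN(C2CCN(S(=O)(=O)c3cccc(Br)c3)CC2)CC1` is likewise reported only at a limit, giving > 5000 nM. Compound 2 `COc1ccccc1-c1cccc(S(=O)(=O)N2CCC(N3CCC(C)CC3)CC2)c1` gives > 5000 nM in this assay, again a limit rather than a number. The steps among these three are therefore unreadable: a step that the two limits leave unreadable from compound 1 to compound 2, a step that the two limits leave unreadable from compound 1 to compound 3 and a step that the two limits leave unreadable from compound 2 to compound 3 carry no size, because of the limit of > 5000 nM in this assay, at which 3 of the 3 values shown sit. Compound 4 `CC1CCN(C2CCN(S(=O)(=O)c3cccc(-c4ccccc4)c3)CC2)CC1` differs from compound 3 by phenyl in place of methyl on an aromatic carbon. Among the measured compounds shown here, no measured step bears on this change with a readable size; compound 2 shows only that a 2-methoxyphenyl on an aromatic carbon also leaves the value at the limit. The expectation is thus no step beyond the scatter, and most likely a value once more reported only as a limit. Compound 4 is estimated at 8000 nM, with a range from 3000 nM to 30000 nM. The expected step in this assay is a step that the limit leaves unreadable from compound 3 to compound 4.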

Compound 4, half-maximal inhibitory concentration: > 5000 nM
Compound 4: a limit, no number; the forecaster's own chance of this, stated with the estimate: 85%; the middle value does not contradict the limit.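

Among the compounds shown here, no step to compound 4 from compound 1, compound 2 or compound 3 can be read, because all of these values stop at one limit: the limit of > 5000 nM in this assay, at which 4 of the 4 values shown sit.

The compounds shown leave open whether bromo, methyl, phenyl and 2-methoxyphenyl on the aromatic carbon differ at all in this assay once actual numbers are available.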